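The source may hold more compounds than are shown below. What is called first, only, known or untested is meant among the compounds shown, and "the series" means these compounds.

The series shares one core, carried by compound 1 `O=C(Nc1ccc(Cl)c(C(F)(F)F)c1)Nc1nnc(Sc2ncnc3scc(-c4ccncc4)c23)s1`, which in a functional assay on T47D cells (Homo sapiens) for antiproliferative activity, read by MTT assay, with a stated time of 48 h (a lower number here means a stronger inhibitor, a higher number a weaker inhibitor), gives 28000 nM. Compound 2 `COc1cccc(NC(=O)Nc2nnc(Sc3ncnc4scc(-c5ccncc5)c34)s2)c1`, with a 3-methoxyphenyl in place of the 4-chloro-3-(trifluoromethyl)phenyl on the amide-type nitrogen, gives 56900 nM, so that there is a 2.0-fold higher number from compound 1 to compound 2 (0.31 log units; beyond the scatter). Among the two numbers so far, compound 2 therefore stands at the highest one, its nearest neighbour being compound 1 at the lower number.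

Compound 3 `O=C(Nc1cccc(F)c1)Nc1nnc(Sc2ncnc3scc(-c4ccncc4)c23)s1` is the next member. Relative to compound 2 the change is fluoro in place of methoxy on an aromatic carbon, a single heavy atom standing where the methoxy stood on the phenyl ring. Within the data shown here, no measured step touches this exact exchange: the one step available, from compound 1 to compound 2 , swaps the whole aryl group and is only modest in size. It shows that changing this aryl moves the number by little, and nothing suggests a larger effect here. For compound 3 the expected step in this assay is a 1.3-fold lower number from compound 2 to compound 3 (0.10 log units; within the scatter), an expectation of no move beyond the scatter. The estimate for compound 3 is 45000 nM, expected to lie between 20000 nM and 100000 nM.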

Compound 3, half-maximal inhibitory concentration: 16700 nM
Estimate against measurement, compound 3: 2.7-fold (0.43 log units) above; measured number below the stated range.
By their numbers in this assay, from the lowest: compounds 3 and 1 (each within the scatter of the next); then compound 2.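

In this assay, fluoro in place of methoxy on an aromatic carbon, meta to a large group, gives a 3.4-fold lower number from compound 2 to compound 3 (0.53 log units; beyond the scatter), so exchanging this one substituent, with the rest of the aryl group unchanged, is enough to move the number beyond the scatter, and compound 2 is the weakest of the three. The 3-fluorophenyl and the 4-chloro-3-(trifluoromethyl)phenyl cannot be told apart here, as there is a 1.7-fold lower number from compound 1 to compound 3 (0.22 log units; within the scatter), so in these three compounds the larger aryl group with its two substituents offers no separation from the single fluoro, and only the methoxy compound stands apart. Nothing given here explains why methoxy and fluoro differ at this carbon.

The compounds shown leave open whether a hydroxy group, an amine, a methyl group or a longer chain such as ethoxy at this same carbon would fall with the methoxy compound or with the fluoro compound. They also leave open whether fluoro or methoxy on the other carbons of the ring, or a chloro group alone, would give the same numbers, and whether any such change could give a clearly lower number than compound 3 does.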